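Aryl Exchange on the Ring Nitrogen: Compound 2 to Compound 3

This account rests on a few compounds, and the source may have more. Where it says the series, first, only, none or still open, it means among the compounds named here.

Measured so far:
Compound 1, `COc1cc2c(Oc3ccc(NC(=O)c4nnn(-c5ccc(C)cc5)c4C(F)(F)F)cc3F)ccnc2cc1OCCCN1CCCC1`, gives 210 nM in a functional assay on MKN-45 cells (Homo sapiens) for cytotoxicity, read by MTT assay, with a stated time of 72 h; on this read-out lower numbers stand for stronger inhibition and higher numbers for weaker inhibition.
Compound 2, `COc1cc2c(Oc3ccc(NC(=O)c4nnn(-c5ccccc5Cl)c4C(F)(F)F)cc3F)ccnc2cc1OCCCN1CCN(C)CC1`, gives 166 nM in this assay.

Compound 2 holds the lower of the two numbers, yet its distance from compound 1 lies within the scatter of this assay, so the two cannot be ordered on this read-out. Compound 3, `COc1cc2c(Oc3ccc(NC(=O)c4nnn(-c5ccc(C)cc5)c4C(F)(F)F)cc3F)ccnc2cc1OCCCN1CCN(C)CC1`, has not yet been measured. It differs from compound 2 in one place: 4-methylphenyl in place of 2-chlorophenyl on an aromatic nitrogen. Within the data shown here, no measured pair in these data differs in only that place, so no step for this change is known. Compound 1 carries the same 4-methylphenyl group on a different tail and gives 210 nM, a number that sits beside that of compound 2. The step of a 1.2-fold higher number from compound 2 to compound 3 (0.08 log units; within the scatter) is therefore expected to be none beyond the scatter, in no particular direction. Compound 3 is estimated at 200 nM, with a range from 90 nM to 450 nM.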

Compound 3, half-maximal inhibitory concentration: 140 nM
The estimate for compound 3 lay 1.4-fold (0.15 log units) above the measured number; measured number inside the range.
By their numbers in this assay, from the lowest: compounds 3, 2 and 1 (each within the scatter of the next).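

In this assay, 4-methylphenyl in place of 2-chlorophenyl on the aromatic nitrogen gives a 1.2-fold lower number from compound 2 to compound 3 (0.07 log units; within the scatter), so this first direct comparison at this position shows no difference that can be told from the scatter. Among these compounds, compound 3 also gives the first direct comparison on the tail, where 4-methylpiperazin-1-yl in place of pyrrolidin-1-yl gives a 1.5-fold lower number from compound 1 to compound 3 (0.18 log units; within the scatter), again with no difference that can be told from the scatter. Nothing measured alongside these compounds bears on these results.

The aryl exchange alters both the substituent and its place on the ring, so the two cannot be separated without groups such as 2-methylphenyl or 4-chlorophenyl. As far as these compounds go, whether a pyridine ring on the aromatic nitrogen, or a morpholine at the end of the tail, would give a step beyond the scatter also stays open.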